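A few compounds are considered here, and "the series" means these few. Any claim that something is new, unique, unknown or untested is made for them only; others in the source may bear on it.

Measured in a functional assay on HUVEC cells (Homo sapiens) for inhibition, read by microscopy and crystal violet staining, with a stated time of 20 h; a higher number here means a weaker inhibitor, a lower number a stronger inhibitor:
compound 1 `COCC1Oc2ccc(-c3oc4cc(O)cc(O)c4c(=O)c3OC)cc2OC1c1ccc(O)c(OC)c1`: 10900 nM
compound 2 `COCC1Oc2ccc(-c3oc4cc(OC)cc(O)c4c(=O)c3O)cc2OC1c1ccc(O)c(OC)c1`: 7300 nM

Compound 2 stands within the scatter of compound 1, so these two values show no separation. Compound 3 `COCC1Oc2ccc(-c3oc4cc(O)cc(O)c4c(=O)c3O)cc2OC1c1ccc(O)c(OC)c1` follows from compound 2 by hydrogen in place of methyl on an oxygen on an aromatic ring, that is, methoxy to hydroxy. Going by the values given here, no measured pair differs in one place alone, so no measured step informs this change. In this assay, no step beyond the scatter is expected. The estimated step is a 1.2-fold lower number from compound 2 to compound 3 (0.09 log units; within the scatter). Compound 3 is expected at 6000 nM, with an estimated range of 2500 nM to 15000 nM.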

Compound 3, half-maximal inhibitory concentration: 10500 nM
Beside the measured number, compound 3's estimate is 1.8-fold (0.24 log units) below it; measured number inside the range.
By their numbers in this assay, from the lowest: compounds 2, 3 and 1 (each within the scatter of the next).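

In this assay, hydrogen in place of methyl on an oxygen on an aromatic ring gives a 1.4-fold higher number from compound 2 to compound 3 (0.16 log units; within the scatter) and, at a different oxygen, a 1.0-fold lower number from compound 1 to compound 3 (0.02 log units; within the scatter) as the second step. Both steps lie within the scatter, so this change separates compound 3 from neither methyl ether, at either oxygen, which compound 1 and compound 2 alone could not show. No measurement here offers an explanation for this.

Going by these compounds, whether a longer chain such as ethyl or propyl on these oxygens would shift the number stays open. So does the effect of an amine in place of the hydroxy.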